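Fluorine pattern on the cinnamoyl aryl ring of compound 3

The source may hold more compounds than are shown below. What is called first, only, known or untested is meant among the compounds shown, and "the series" means these compounds.

The series shares one core, seen in compound 1 `C#CCOc1cccc(/C=C/C(=O)Nc2cc(C(=O)c3cc(OC)c(OC)c(OC)c3)ccc2OC)c1`, and varies the aryl group carried on a double-bonded chain carbon bound to a double-bonded chain carbon. In a functional assay on PC-3 cells (Homo sapiens) for cytotoxicity, read by MTT assay, with a stated time of 72 h (a lower number here means a stronger inhibitor, a higher number a weaker inhibitor), compound 1 gives 13100 nM. Compound 2 `COc1ccc(C(=O)c2cc(OC)c(OC)c(OC)c2)cc1NC(=O)/C=C/c1ccc(F)cc1` gives 3200 nM in this assay, and compound 3 `COc1ccc(C(=O)c2cc(OC)c(OC)c(OC)c2)cc1NC(=O)/C=C/c1ccc(C(F)(F)F)cc1` gives 3500 nM. Among these three numbers compound 3 stands second highest; its nearest neighbour is compound 2, and the two lie within the scatter of each other, while compound 1 is the furthest away. The aryl swaps carry the larger movements: a 4.1-fold lower number from compound 1 to compound 2 (0.61 log units; beyond the scatter) and a 3.7-fold lower number from compound 1 to compound 3 (0.57 log units; beyond the scatter). Between the two fluorinated aryl groups the step is small, a 1.1-fold higher number from compound 2 to compound 3 (0.04 log units; within the scatter).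

Compound 4 `COc1ccc(C(=O)c2cc(OC)c(OC)c(OC)c2)cc1NC(=O)/C=C/c1ccc(F)c(F)c1` differs from compound 3 in one place: 3,4-difluorophenyl in place of 4-(trifluoromethyl)phenyl on a double-bonded chain carbon bound to a double-bonded chain carbon. Among the measured compounds shown here, the only step that bears on it directly is the swap of trifluoromethyl for fluoro, which stayed within the scatter, so a second fluorine on the ring is expected to move the number little. The estimate for compound 4 in this assay is therefore 3000 nM, with a range from 1200 nM to 8000 nM, which amounts to an expected step of a 1.2-fold lower number from compound 3 to compound 4 (0.07 log units; within the scatter).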

Compound 4, half-maximal inhibitory concentration: 8300 nM
Estimate against measurement, compound 4: 2.8-fold (0.44 log units) below, and the stated range ends below it.
By their numbers in this assay, from the lowest: compounds 2 and 3 (each within the scatter of the next); then compounds 4 and 1 (each within the scatter of the next).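

In this assay, adding a single fluoro to the aryl ring of compound 2 gives a 2.6-fold higher number from compound 2 to compound 4 (0.41 log units; beyond the scatter) and so moves the number beyond the scatter, whereas the earlier exchange of fluoro for trifluoromethyl on that ring stayed within it. The two fluorinated rings of compound 3 and compound 4 are also told apart, with a 2.4-fold higher number from compound 3 to compound 4 (0.38 log units; beyond the scatter) on the change to 3,4-difluorophenyl, and the step to the propargyloxy compound, a 1.6-fold lower number from compound 1 to compound 4 (0.20 log units; within the scatter), shows that the advantage of compound 2 and compound 3 over compound 1 is not shared by compound 4, so fluorination of this aryl group does not lower the number in every case. No measurement among the data shown explains why the second fluoro raises the number here.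

The compounds shown leave open whether a chloro, a methoxy or an amino group in place of the added fluoro would read like compound 2 or like compound 4. They also leave open whether the same order holds in any cell line other than the one tested, since every number here comes from a single assay.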